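The source may hold more compounds than are shown below. What is called first, only, known or untested is meant among the compounds shown, and "the series" means these compounds.

Measured so far in a functional assay on HL-60 cells (Homo sapiens) for cytotoxicity, read by WST assay, with a stated time of 48 h (on this read-out higher numbers stand for an effect only at larger amounts of compound and lower numbers for an effect already at smaller amounts), for this series:
- compound 1 `O=C1OC[C@H](Cc2ccccc2)[C@H]1Cc1ccccc1O` gives 83000 nM
- compound 2 `COc1ccccc1C[C@H]1C(=O)OC[C@@H]1Cc1ccccc1` gives 79000 nM
- compound 3 `COc1cccc(C[C@H]2C(=O)OC[C@@H]2Cc2ccccc2)c1` gives 66000 nM

Compound 3 sits level with compound 1 and compound 2, all three numbers lying within the scatter of each other. Compound 4 `O=C1OC[C@H](Cc2ccccc2)[C@H]1Cc1cccc(C(F)(F)F)c1` carries trifluoromethyl in place of methoxy on an aromatic carbon, meta to a large group (trifluoromethyl in place of methoxy on an aromatic carbon). For the measured compounds named here, the one measured step between compounds differing in a single place (a 1.1-fold lower number from compound 1 to compound 2 (0.02 log units; within the scatter)) stays within the scatter, and it bears on this change only indirectly. Going by the values given here, no measured step exchanges these two groups. In this assay no step beyond the scatter is expected, the estimated change being (a 1.2-fold lower number from compound 3 to compound 4 (0.08 log units; within the scatter)). Compound 4 is expected at 55000 nM within an estimated range of 25000 nM to 110000 nM here.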

Compound 4, half-maximal effective concentration: 34000 nM
Estimate against measurement, compound 4: 1.6-fold (0.21 log units) above, and the stated range covers the measured number.
By their numbers in this assay, from the lowest: compounds 4, 3, 2 and 1 (each within the scatter of the next, the first and the last beyond it).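

In this assay, for the compounds shown here, the exchange at this aromatic carbon, meta to a large group, gives a first measured step for replacing methoxy, with its hydrogen-bond acceptor, by trifluoromethyl, with none (a 1.9-fold lower number from compound 3 to compound 4 (0.29 log units; within the scatter)). Even this change of group stays within the scatter, so the position shows no measurable dependence on which of these two groups it carries. Nothing available explains the step or its size. As far as these compounds go, whether an amine or a carboxylic acid at this aromatic carbon would move the number beyond the scatter remains open. So does the outcome of the same exchange on another aromatic carbon of the series.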